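A few compounds are considered here, and "the series" means these few. Any claim that something is new, unique, unknown or untested is made for them only; others in the source may bear on it.

Two compounds of the series carry measurements in an assay on isolated protein for inhibition of Calpain-1 catalytic subunit (Sus scrofa), read by FRET (a lower number here means a stronger inhibitor, a higher number a weaker inhibitor), so far. Compound 1 `O=C(O)/C(S)=C/c1c[nH]c2ccc(F)cc12` gives 800 nM, the lowest of the two numbers. Among the measured compounds shown here, compound 2 `O=C(O)/C(S)=C/c1ccc(I)cc1` gives 2200 nM in this assay, a number that stands clearly higher than that of compound 1, but the two compounds differ in more than one place and no single step connects them.

Compound 3 `O=C(O)/C(S)=C/c1c[nH]c2ccc(I)cc12` has not yet been measured. It departs from compound 1 by one change, (iodo in place of fluoro on an aromatic carbon), that is, iodo in place of fluoro on an aromatic carbon. For the measured compounds named here, no single-point step between measured compounds is available to read a size from, and compound 2 carries iodo on a different core, so it does not set the size of this change either. The expectation is therefore cautious: no step beyond the scatter, with a slight lean toward a lower number, so that compound 3 is expected at 600 nM in this assay, within 200 nM to 2000 nM, which amounts to an expected step of a 1.3-fold lower number from compound 1 to compound 3 (0.12 log units; within the scatter).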

Compound 3, half-maximal inhibitory concentration: 100 nM
Compound 3: the middle estimate sits 6.0-fold (0.78 log units) above what was measured; the measured number lies below the stated range.
By their numbers in this assay, from the lowest: compound 3; then compound 1; then compound 2.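

In this assay, among the compounds shown here, iodo in place of fluoro gives an 8.0-fold lower number from compound 1 to compound 3 (0.90 log units; beyond the scatter), the first step that can be read at a single place. It shows that the number responds to the group on this aromatic carbon, which lies meta to a fused ring and para to a fused ring within a fused system of two rings. The exchange swaps one heavy atom for one heavy atom, with no ring, hydrogen-bond donor, hydrogen-bond acceptor or net charge leaving or entering, yet the step lies beyond the scatter, and nothing available bears on what underlies it.

The compounds shown leave open whether the number falls steadily through the halogens, since chloro and bromo on this carbon have no values here, and whether a non-halogen group such as methoxy, nitrile or an amine would fit the same trend. For the compounds shown here, they also leave open whether the same exchange gives a step of similar size on another core, because only this one pair differs in a single place.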